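A few compounds are considered here, and "the series" means these few. Any claim that something is new, unique, unknown or untested is made for them only; others in the source may bear on it.

Of the compounds shown here, three built on one shared core have been measured in an assay on isolated protein for displacement of a labelled ligand from metabotropic glutamate receptor 5 (Homo sapiens), with a stated time of 60 min, tested at 1 uM; a lower number here means less inhibition, a higher number more inhibition at the concentration tested (going by the name of the read-out). Compound 2 `COc1ccc2ncc(S(=O)(=O)c3ccc(Cl)c(Cl)c3)c(N3CCC(C)CC3)c2c1` gives 87%, the highest of the three numbers. Compound 3 `COc1ccc2ncc(S(=O)(=O)c3cc(C)cc(C)c3)c(N3CCC(C)CC3)c2c1` gives 79%, and the step of a number 8 percentage points lower from compound 2 to compound 3 (within the scatter) lies within the scatter. Compound 1 `COc1ccc2ncc(S(=O)(=O)c3ccc(OC)c(OC)c3)c(N3CCC(C)CC3)c2c1` gives -3%, far lower: the step of a number 90 percentage points higher from compound 1 to compound 2 (beyond the scatter) and the step of a number 82 percentage points higher from compound 1 to compound 3 (beyond the scatter) are both large. Compound 4 `Cc1ccc2ncc(S(=O)(=O)c3ccc(Cl)c(Cl)c3)c(N3CCC(C)CC3)c2c1` differs from compound 2 by methyl in place of methoxy on an aromatic carbon. Among the compounds with values here, every measured step changed the group on the sulfonyl sulfur, whereas this change sits on the fused two-ring system, so no step bears directly on it, and no change beyond the scatter is expected. Compound 4 is therefore estimated at 80%, within 55% to 95%, an expected step of a number 7 percentage points lower from compound 2 to compound 4 (within the scatter).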

Compound 4, a percentage reported as inhibition, at one concentration (the size of the read-out at that concentration, not a potency): 82%
Estimate against measurement, compound 4: 2 percentage points below, and the stated range covers the measured number.
By their numbers in this assay, from the lowest: compound 1; then compounds 3, 4 and 2 (each within the scatter of the next).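

Within the data shown here, this is the first measured change on the fused two-ring system rather than on the sulfonyl sulfur: in this assay the swap of methyl in place of methoxy is a number 5 percentage points lower from compound 2 to compound 4 (within the scatter) and so makes no readable difference. With the 3,4-dichlorophenyl group held fixed, this position can lose the methoxy oxygen and keep its number within the scatter. No measurement at hand explains this result.

Still open, going by these compounds, is whether a different group here, such as an amine or a longer alkoxy chain, would leave the number level as well. Also open, on these data alone, is whether the same swap would read alike with 3,5-dimethylphenyl on the sulfonyl sulfur.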